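Dienone coumarin triazole hybrids: methoxy removal on COLO 205

The source may hold more compounds than are shown below. What is called first, only, known or untested is meant among the compounds shown, and "the series" means these compounds.

In a functional assay on COLO 205 cells (Homo sapiens) for inhibition, read by sulforhodamine B assay, with a stated time of 48 h, tested at 50 uM (a lower number here means less inhibition of growth, a higher number more inhibition of growth at the concentration tested), compound 1 `COc1cccc(/C=C/C(=O)/C=C/c2ccc(OCc3cn(CCCCCOc4cc(=O)oc5ccccc45)nn3)c(OC)c2)c1` gives 34%, compound 2 `COc1ccc(/C=C/C(=O)/C=C/c2ccc(OCc3cn(CCCOc4cc(=O)oc5ccccc45)nn3)c(OC)c2)cc1OC` gives 65% and compound 3 `COc1cc(/C=C/C(=O)/C=C/c2ccccc2)ccc1OCc1cn(CCCCCOc2cc(=O)oc3ccccc23)nn1` gives 22%. The difference between the cores of compound 1 and compound 2 is not broken down here. The change hydrogen in place of methoxy on an aromatic carbon brings a number 12 percentage points lower from compound 1 to compound 3 (beyond the scatter). Compound 4 `COc1ccc(/C=C/C(=O)/C=C/c2ccc(OCc3cn(CCCOc4cc(=O)oc5ccccc45)nn3)c(OC)c2)cc1` is not yet measured; it arises from compound 2 by hydrogen in place of methoxy on an aromatic carbon, the same kind of change, the site here being ortho to a methoxy group (2 heavy atoms) as well as meta to a large group. Among the measured compounds shown here, for compound 4 the step of a number 12 percentage points lower from compound 2 to compound 4 (beyond the scatter) is expected to be of like size, because a number 12 percentage points lower from compound 1 to compound 3 (beyond the scatter) is the only precedent, and one example is a thin basis. Compound 4 is therefore estimated at 53%, between 40% and 66%.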

Compound 4, percent growth inhibition at one concentration: 53%
Compound 4: middle estimate and measured number agree at the digits printed; measured number inside the range.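

In this assay, the change from 3,4-dimethoxyphenyl to 4-methoxyphenyl brings a number 12 percentage points lower from compound 2 to compound 4 (beyond the scatter) on the core of compound 2. Among the compounds shown here, with only two pairs, tested at a single concentration, this does not establish a rule for other cores or other sites on the aromatic ring. On these two cores, the change carried over at the same size: the same change on two cores in this assay, a number 12 percentage points lower (beyond the scatter) from compound 1 to compound 3 and a number 12 percentage points lower (beyond the scatter) from compound 2 to compound 4, 0 percentage points apart, within the scatter of two such steps

The compounds shown leave open whether a hydroxy group, an amine or a fluorine atom at the same site would shift growth inhibition as hydrogen does. On these data alone, whether the step would hold with a longer chain linking the coumarin to the rest of the molecule also remains open.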